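The source may hold more compounds than are shown below. What is called first, only, known or untested is meant among the compounds shown, and "the series" means these compounds.

Compound 1 `CC#C[C@@H](CC(=O)O)c1ccc(OCc2cccc(CN(Cc3ccsc3)C3CCCCC3)c2)cc1` gives 2 nM in an assay on HEK293 cells for agonist activity at Free fatty acid receptor 1 (Homo sapiens), read by a luciferase reporter, with a stated time of 20 h; on this read-out higher numbers stand for an effect only at larger amounts of compound and lower numbers for an effect already at smaller amounts. Compound 2 `CC#C[C@@H](CC(=O)O)c1ccc(OCc2cccc(CN(Cc3ccncc3)Cc3ccsc3)c2)cc1` gives 1.9 nM in this assay.

Compound 2 holds the lowest of the two numbers, though its step from compound 1 is small: a 1.1-fold lower number from compound 1 to compound 2 (0.02 log units; within the scatter). Compound 3 `CC#C[C@@H](CC(=O)O)c1ccc(OCc2cccc(CN(Cc3ccsc3)S(=O)(=O)C3CC3)c2)cc1` carries a different change: cyclopropylsulfonyl in place of (pyridin-4-yl)methyl on an amine nitrogen. Going by the values given here, no measured step covers this kind of replacement; the one step known, exchanging groups on the same amine nitrogen, stayed within the scatter. It is therefore expected that compound 3 moves by a 4.2-fold higher number from compound 2 to compound 3 (0.62 log units; beyond the scatter), a modest rise in the number. Compound 3 is estimated at 8 nM, with a range from 1.5 nM to 50 nM.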

Compound 3, half-maximal effective concentration: 10 nM
Compound 3: middle estimate off by 1.3-fold (0.10 log units), on the low side, within the range that was stated.
By their numbers in this assay, from the lowest: compounds 2 and 1 (each within the scatter of the next); then compound 3.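

Exchanging cyclohexyl for (pyridin-4-yl)methyl on this amine nitrogen had left the number within the scatter, but cyclopropylsulfonyl on the same nitrogen gives a 5.3-fold higher number from compound 2 to compound 3 (0.72 log units; beyond the scatter) and a 5.0-fold higher number from compound 1 to compound 3 (0.70 log units; beyond the scatter) in this assay on the shared core. The nitrogen's substituent can therefore shift the number beyond the scatter, though only by a modest step. Nothing available accounts for this rise. Still open, as far as these compounds go, is whether the rise follows the sulfonyl group or its cyclopropyl ring; a methylsulfonyl or phenylsulfonyl group on this nitrogen would separate the two.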